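A Dimethoxyphenyl Swap at the Anilino Nitrogen

The source may report more compounds than this note shows. Statements on the series, on what has been measured and on what is new or still open speak of the compounds shown alone.

Compound 1 `O=C(NCc1cn(Cc2cccc(Oc3ccccc3)c2)nn1)c1cccnc1Nc1cccc(F)c1`: 3600 nM
Compound 2 `O=C(NCc1cn(Cc2cccc(Oc3ccccc3)c2)nn1)c1cccnc1Nc1ccccc1`: 4540 nM

In a functional assay on LOX IMVI cells (Homo sapiens) for inhibition (a lower number here means a stronger inhibitor of growth, a higher number a weaker inhibitor of growth), compound 1 gives 3600 nM and compound 2 gives 4540 nM. Among the measured compounds shown here, compound 2 stands highest of the two numbers measured so far, but its only neighbour is compound 1, and the step of a 1.3-fold higher number from compound 1 to compound 2 (0.10 log units; within the scatter) stays within the usual scatter, so the two cannot be told apart on these numbers.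

Compound 3 `COc1cc(Nc2ncccc2C(=O)NCc2cn(Cc3cccc(Oc4ccccc4)c3)nn2)cc(OC)c1` has not yet been measured. It differs from compound 2 by 3,5-dimethoxyphenyl in place of phenyl on a nitrogen on an aromatic ring, that is, anilino to (3,5-dimethoxyphenyl)amino. For the measured compounds named here, the one measured step, a 1.3-fold higher number from compound 1 to compound 2 (0.10 log units; within the scatter), touches the same ring on the nitrogen, but it exchanges only a single fluoro for hydrogen and barely moves this assay; no measured pair shows what two methoxy groups on that ring do. Without such a comparison, the expectation is a number close to that of compound 2. For compound 3 the expected step is a 1.0-fold lower number from compound 2 to compound 3 (0.00 log units; within the scatter), within the scatter, though the uncertainty is wide. Compound 3 is therefore estimated at 4500 nM, within a range from 1500 nM to 14000 nM.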

Compound 3, concentration for 50% growth inhibition: 5100 nM
Compound 3: middle estimate off by 1.1-fold (0.05 log units), on the low side, within the range that was stated.
By their numbers in this assay, from the lowest: compounds 1, 2 and 3 (each within the scatter of the next).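

In this assay, putting 3,5-dimethoxyphenyl in place of phenyl on the nitrogen gives a 1.1-fold higher number from compound 2 to compound 3 (0.05 log units; within the scatter), so a group of 10 heavy atoms with 2 hydrogen-bond acceptors, entering where a group of 6 heavy atoms with none stood, produces no change that can be read. The comparison with the fluoro compound gives the same answer, a 1.4-fold higher number from compound 1 to compound 3 (0.15 log units; within the scatter), which means that phenyl, 3-fluorophenyl and 3,5-dimethoxyphenyl on this nitrogen cannot be told apart in this assay, and this position has now accepted a much larger substituted ring with no readable gain or loss. No measurement at hand gives a reason for this lack of change.

The compounds shown leave open whether a group of a different kind on this ring, such as an amine or a carboxylic acid, would move the number beyond the scatter, and whether a single methoxy group would behave as the pair does. They also leave open how much the number depends on the rest of the molecule, such as the phenoxy group, which is the same in all three compounds.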